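Growing the side chain again: isopropyl to cyclohexyl

The source may report more compounds than this note shows. Statements on the series, on what has been measured and on what is new or still open speak of the compounds shown alone.

Compound 1 `CCOc1ccc(C)c(-c2cccc(COc3ccc(OCC(=O)O)c(F)c3)c2)c1` gives 220 nM in a functional assay on CHO cells for agonist activity at Free fatty acid receptor 1 (Homo sapiens), read by FLIPR and calcium flux; a higher number here means that more compound is needed for the effect, a lower number that less compound is needed.
Compound 2 `Cc1ccc(OCC(C)C)cc1-c1cccc(COc2ccc(OCC(=O)O)c(F)c2)c1` gives 1450 nM in this assay.

Within the data shown here, of the two measured compounds, compound 2 gives the higher number; its only neighbour is compound 1, reached by the single measured step, a 6.6-fold higher number from compound 1 to compound 2 (0.82 log units; beyond the scatter). Compound 3 `Cc1ccc(OCC2CCCCC2)cc1-c1cccc(COc2ccc(OCC(=O)O)c(F)c2)c1` takes the same place one step further: cyclohexyl in place of isopropyl on a saturated chain carbon bound to an oxygen on an aromatic ring. Among the measured compounds shown here, the one step on hand already enlarged the group on that chain carbon and raised the number in this assay, and cyclohexyl enlarges it once more. A further rise in this assay is therefore expected, although nothing measured shows how far the pattern continues or whether it flattens, so the range is kept wide. Compound 3 is expected to give about 3000 nM, between 1000 nM and 9000 nM, which amounts to an estimated step of a 2.1-fold higher number from compound 2 to compound 3 (0.32 log units; beyond the scatter).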

Compound 3, half-maximal effective concentration: 910 nM
For compound 3 the middle estimate is 3.3-fold (0.52 log units) above the measured one, and the stated range ends above it.
By their numbers in this assay, from the lowest: compound 1; then compounds 3 and 2 (each within the scatter of the next).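

Replacing isopropyl with cyclohexyl on this chain carbon gives in this assay a 1.6-fold lower number from compound 2 to compound 3 (0.20 log units; within the scatter) and so does not continue the rise seen with the first enlargement, even though the group now holds a ring and more heavy atoms. The larger group still stands apart from the small methyl of compound 1, with a 4.1-fold higher number from compound 1 to compound 3 (0.62 log units; beyond the scatter) for the same place, so both enlarged side chains keep a higher number than compound 1 does. No measurement on hand explains why the number stops rising here.

From the compounds shown here alone, it remains open whether an aromatic phenyl ring in place of cyclohexyl would read the same way in this assay. An amine or a carboxylic acid on this chain, or simply a longer chain, could also show whether this place accepts more than plain saturated carbon groups.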